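Sulfonamide nitrogen variation: working notes toward compound 4

The compounds below may be only part of what the source reports. "The series", "measured", "known", "first", "only" and "open" are said of these compounds alone.

Measured so far in an assay for inhibition of 6-phosphofructo-2-kinase/fructose-2,6-bisphosphatase 3 (Homo sapiens), read by ADP-Glo, with a stated time of 2 h; on this read-out higher numbers stand for weaker inhibition and lower numbers for stronger inhibition:
- compound 1 `CNS(=O)(=O)c1ccccc1Nc1cc(-c2ccc3ccn(C)c3c2)c2nccnc2c1`: 104 nM
- compound 2 `CN(C)S(=O)(=O)c1ccccc1Nc1cc(-c2ccc3ccn(C)c3c2)c2nccnc2c1`: 94 nM
- compound 3 `Cn1ccc2ccc(-c3cc(Nc4ccccc4S(=O)(=O)Nc4cncnc4)cc4nccnc34)cc21`: 1690 nM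

Compound 3 gives the highest number of the three. Its nearest neighbour is compound 1 a 16-fold higher number from compound 1 to compound 3 (1.21 log units; beyond the scatter), and the gap to compound 2 is of similar size an 18-fold higher number from compound 2 to compound 3 (1.25 log units; beyond the scatter). Between compound 1 and compound 2 the step is a 1.1-fold lower number from compound 1 to compound 2 (0.04 log units; within the scatter).

Compound 4 `CN1CCC(NS(=O)(=O)c2ccccc2Nc2cc(-c3ccc4ccn(C)c4c3)c3nccnc3c2)C1` differs from compound 3 in one place: 1-methylpyrrolidin-3-yl in place of pyrimidin-5-yl on a sulfonamide nitrogen. The measured steps bearing on this are those from compound 1 and compound 2 to compound 3, both large, which show that the aromatic pyrimidin-5-yl on the sulfonamide nitrogen goes with much weaker inhibition than methyl or dimethylamino there. Compound 4 carries a non-aromatic ring at that position instead, so a return toward the numbers of compound 1 and compound 2 is expected, though not necessarily all the way. For compound 4 the expected step is a 6.8-fold lower number from compound 3 to compound 4 (0.83 log units; beyond the scatter). Compound 4 is therefore estimated at 250 nM, with a range from 70 nM to 900 nM.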

Compound 4, half-maximal inhibitory concentration: 33 nM
For compound 4 the middle estimate is 7.6-fold (0.88 log units) above the measured one; measured number outside the range, below it.
By their numbers in this assay, from the lowest: compound 4; then compounds 2 and 1 (each within the scatter of the next); then compound 3.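

The sulfonamide nitrogen accepts more than a return to the level of the small groups. Moving to 1-methylpyrrolidin-3-yl gives a large gain (a 51-fold lower number from compound 3 to compound 4 (1.71 log units; beyond the scatter)) and also modest gains over both simple variants (a 3.2-fold lower number from compound 1 to compound 4 (0.50 log units; beyond the scatter); a 2.8-fold lower number from compound 2 to compound 4 (0.45 log units; beyond the scatter)), making compound 4 the strongest inhibitor of the four. Since pyrimidin-5-yl and 1-methylpyrrolidin-3-yl have the same heavy-atom count, the weak number of compound 3 does not follow from that count alone, but no supporting measurement explains the difference between the two rings.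

As far as these compounds go, it remains open whether the gain depends on the ring nitrogen or on its methyl group. Cyclopentyl, pyrrolidin-3-yl without the methyl, piperidin-4-yl and an open-chain 2-(dimethylamino)ethyl group at this position would separate these features.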